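Branching the chain on the aromatic nitrogen

A few compounds are considered here, and "the series" means these few. Any claim that something is new, unique, unknown or untested is made for them only; others in the source may bear on it.

Three compounds share one core and differ in the ring attached to it. In an in vitro functional assay on cells (Fibroblast) for agonist activity at Alpha-1D adrenergic receptor (Homo sapiens) (a lower number here means that less compound is needed, a higher number that more compound is needed for the effect), compound 1 `CCCCn1ncnc1-c1ccccc1NCC1=NCCN1` gives 398 nM. For compound 2 `Cc1n[nH]c(-c2ccccc2NCC2=NCCN2)n1` this assay reports < 5020 nM, which is the limit of < 5020 nM in this assay, at which 1 of the 3 values shown sits. For compound 3 `CCn1nccc1-c1ccccc1NCC1=NCCN1` this assay reports < 100000 nM, which is the limit of < 100000 nM in this assay, at which 1 of the 3 values shown sits. Compound 3 thus stands without a number of its own: of the three values shown, two are limits and only compound 1 carries a measured figure, so no order of compound 3 against the others can be drawn. Compound 4 `CC(C)n1nccc1-c1ccccc1NCC1=NCCN1` differs from compound 3 by methyl in place of hydrogen on a saturated chain carbon bound to an aromatic nitrogen and a saturated chain carbon. For the measured compounds named here, no step between measured compounds contains this change, so its size and direction remain open; the limit of compound 3 leaves room in either direction. Compound 4 is expected to give 20000 nM, within 2000 nM to 100000 nM, which would mean an estimated step that the limit leaves unreadable from compound 3 to compound 4, with a fair chance that this assay once more reports only a limit.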

Compound 4, half-maximal effective concentration: < 100000 nM
Compound 4: no number, only a limit; the forecaster's own chance of this, stated with the estimate: 50%; the middle value lies beyond the limit too.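

Compound 3 and compound 4 each carry only a limit in this assay, and the step from ethyl to isopropyl cannot be read from them. The compounds shown leave open whether branching the chain on the aromatic nitrogen changes the value at all, and in which direction.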